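From a Nitrobenzamide to an Ethyl Carbamate

The compounds below may be only part of what the source reports. "The series", "measured", "known", "first", "only" and "open" are said of these compounds alone.

Compound 1 `Cc1cc(S(=O)(=O)N2C(=O)N[C@@H](c3ccccc3)C2C)ccc1NC(=O)c1ccc([N+](=O)[O-])cc1` was tested in a functional assay on NCI-H460 cells (Homo sapiens) for cytotoxicity, read by MTT assay (a higher number here means a weaker inhibitor, a lower number a stronger inhibitor), where compound 1 gives > 10000 nM. That value is a limit of the assay and not a number, so compound 1 can only be placed at the weak end of what the assay reports. Compound 2 `CC1[C@H](c2ccccc2)NC(=O)N1S(=O)(=O)c1ccc(NC(=O)c2ccc([N+](=O)[O-])cc2)c(Cl)c1` carries chloro in place of methyl on an aromatic carbon, and in this assay compound 2 gives > 10000 nM. That value too is a limit. The step that the two limits leave unreadable from compound 1 to compound 2 cannot be read in size because both values sit at the limit of > 10000 nM in this assay, at which 2 of the 2 values shown sit.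

Compound 3 `CCOC(=O)Nc1ccc(S(=O)(=O)N2C(=O)N[C@@H](c3ccccc3)C2C)cc1C` differs from compound 1 at the carbonyl carbon whose other neighbour is an amide-type nitrogen: ethoxy in place of 4-nitrophenyl on a carbonyl carbon. For the measured compounds named here, no measured step touches this place, and the one step that was measured is itself unreadable, so the data give no guide to the direction or size of this change. With compound 1 at a limit, any step from it can only be guessed. Compound 3 is expected to stay near the limit, at about 15000 nM, with a range from 3000 nM to 60000 nM. The step that the limit leaves unreadable from compound 1 to compound 3 is therefore expected to be small, and most likely the assay will again report only a limit for compound 3.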

Compound 3, half-maximal inhibitory concentration: 5000 nM
Estimate against measurement, compound 3: 3.0-fold (0.48 log units) above, within the range that was stated.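

In this assay compound 3 gives 5000 nM, the only actual number among the compounds shown. Compound 1 and compound 2 each stand at a limit: the limit of > 10000 nM in this assay, at which 2 of the 3 values shown sit. With ethoxy in place of 4-nitrophenyl on a carbonyl carbon, the data show an at least 2.0-fold lower number from compound 1 to compound 3 (0.30 log units; that floor lies within the scatter), so in this pair a value can be read even though the aromatic ring and the nitro group of the old group are gone and only 3 heavy atoms enter where 9 leave. Compound 1 gives > 10000 nM, which is a limit and not a number, so that step is only a floor, and since the floor lies within the scatter, it does not establish a real difference between the two compounds.

From the compounds shown here alone, with a single change at this place, it remains open which part of the old group matters, and what a plain phenyl, a longer chain such as butoxy, or an amine on the same carbonyl carbon would give. Going by these compounds, the step from compound 1 to compound 2 cannot be read, so the effect of chloro in place of methyl on an aromatic carbon also remains open.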